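The source may report more compounds than this note shows. Statements on the series, on what has been measured and on what is new or still open speak of the compounds shown alone.

Measured in a functional assay on HepG2 cells (Homo sapiens) for cytotoxicity, read by MTT assay, with a stated time of 24 h; on this read-out higher numbers stand for weaker inhibition and lower numbers for stronger inhibition:
- compound 1 `O=C1/C(=C/c2ccncc2)CN(S(=O)(=O)c2ccc(C(F)(F)F)cc2)C/C1=C\c1ccccc1F`: 4030 nM
- compound 2 `O=C1/C(=C/c2ccncc2)CN(S(=O)(=O)c2ccc(Br)cc2)C/C1=C\c1ccccc1F`: 9300 nM

Compound 2, at 9300 nM, has the higher of the two numbers, so it is the weaker inhibitor in this assay. The next compound is compound 3 `N#Cc1ccc(S(=O)(=O)N2C/C(=C\c3ccncc3)C(=O)/C(=C/c3ccccc3F)C2)cc1`, which keeps the core of compound 2 and carries one change: cyano in place of bromo on an aromatic carbon. In words, cyano replaces bromo on an aromatic carbon, taking 4-bromophenyl to 4-cyanophenyl.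

For the measured compounds named here, no measured compound carries cyano. Going by the values given here, the only guide is the modest step at this same place, a 2.3-fold higher number from compound 1 to compound 2 (0.36 log units; beyond the scatter), and it involves a different group. A step no larger than that one is expected in this assay, towards a lower number, and it may stay within the scatter. The expected step is a 1.7-fold lower number from compound 2 to compound 3 (0.23 log units; within the scatter). For compound 3 the estimated value is 5500 nM, with an expected range of 2300 nM to 13000 nM.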

Compound 3, half-maximal inhibitory concentration: 4500 nM
The estimate for compound 3 lay 1.2-fold (0.09 log units) above the measured number, within the range that was stated.
By their numbers in this assay, from the lowest: compounds 1 and 3 (each within the scatter of the next); then compound 2.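

In this assay, 4-cyanophenyl in place of 4-bromophenyl gives a change of similar size to the earlier one at this place (a 2.1-fold lower number from compound 2 to compound 3 (0.32 log units; beyond the scatter)), so compound 2 is now set apart from two other groups rather than from trifluoromethyl alone. Cyano in place of trifluoromethyl gives no separable change (a 1.1-fold higher number from compound 1 to compound 3 (0.05 log units; within the scatter)), which leaves bromo as the one group of the three standing apart at this position. Nothing available bears on why these groups fall this way.

As far as these compounds go, whether an amine or a carboxylic acid at this aromatic carbon would move the number beyond the narrow span seen so far remains open. Also open, from the compounds shown here alone, is whether the separation of bromo from cyano and trifluoromethyl would hold with a change elsewhere on the shared core.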